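From Benzyl to Trifluorobenzyl in a Cytotoxicity Test

This account rests on a few compounds, and the source may have more. Where it says the series, first, only, none or still open, it means among the compounds named here.

In an ADME assay on HepG2 cells (Homo sapiens) for cytotoxicity, read by MTT assay, with a stated time of 48 h (on this read-out higher numbers stand for weaker inhibition and lower numbers for stronger inhibition), compound 1 `O=S(=O)(c1ccc(-c2ccc3ncnc(Nc4ccc(OCc5cccc(F)c5)c(Cl)c4)c3c2)cc1)N1CCCCC1` gives > 15000 nM, which is a limit and not a number. Compound 2 `CN(C)S(=O)(=O)c1ccccc1-c1ccc2ncnc(Nc3ccc(OCc4cccc(F)c4)c(Cl)c3)c2c1` gives > 15000 nM, again a limit and not a number. Compound 3 `O=S(=O)(c1ccc(-c2ccc3ncnc(Nc4ccc(OCc5ccccc5)c(Cl)c4)c3c2)cc1)N1CCOCC1` gives > 15000 nM, likewise a limit. Compound 3 thus shares (the limit of > 15000 nM in this assay, at which 3 of the 3 values shown sit), and no measured number places it more exactly.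

Compound 4 `O=S(=O)(c1ccc(-c2ccc3ncnc(Nc4ccc(OCc5cc(F)cc(F)c5F)c(Cl)c4)c3c2)cc1)N1CCOCC1` keeps the rest of compound 3 and changes one group: 2,3,5-trifluorophenyl in place of phenyl on a saturated chain carbon bound to an oxygen on an aromatic ring. In words, 2,3,5-trifluorophenyl stands in place of phenyl on a saturated chain carbon bound to an oxygen on an aromatic ring, so that benzyl becomes 2,3,5-trifluorobenzyl.

Among the measured compounds shown here, no two measured compounds differ in one place, so no measured step can serve as a guide. In this assay no step beyond the scatter is expected in either direction, and this expectation rests on compound 3, which reads > 15000 nM, a limit. The estimated change runs a step that the limit leaves unreadable from compound 3 to compound 4. Compound 4 is estimated at 20000 nM, with an expected range from 9000 nM to 40000 nM. A report of only a limit is the likelier outcome for compound 4.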

Compound 4, half-maximal inhibitory concentration: > 3000 nM
Compound 4: no number, only a limit (the forecaster's own chance of this, stated with the estimate: 80%); the middle value is on the limit's open side.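

In this assay compound 4 gives > 3000 nM, a limit and not a number. Among the compounds shown here, compound 3 is also known only as a limit, so no step from compound 3 to compound 4 can be read. The compounds shown leave open what numerical value any of them would reach in this test, and what 2,3,5-trifluorobenzyl in place of benzyl changes.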